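A few compounds are considered here, and "the series" means these few. Any claim that something is new, unique, unknown or untested is made for them only; others in the source may bear on it.

Measured so far:
compound 1, `CC(C)(C)C(=O)N1Cc2c(NC(=O)c3ccncc3)n[nH]c2C1(C)C`, 110 nM
compound 2, `CN1CCC(C(=O)N2Cc3c(NC(=O)C4CCC4)n[nH]c3C2(C)C)CC1`, 140 nM

Both compounds were tested in a functional assay on A2780 cells (Homo sapiens) for antiproliferative activity, read by fluorescence, with a stated time of 72 h; a lower number here means a stronger inhibitor, a higher number a weaker inhibitor. Compound 2 gives 140 nM, and compound 1 gives 110 nM; the two numbers lie within the usual scatter of each other, so neither can be called the stronger inhibitor.

The next compound, compound 3 `CN1CCC(C(=O)N2Cc3c(NC(=O)c4ccco4)n[nH]c3C2(C)C)CC1`, has not yet been measured. It differs from compound 2 in one place: furan-2-yl in place of cyclobutyl on a carbonyl carbon. The cyclobutyl leaves and furan-2-yl enters on a carbonyl carbon whose other neighbours are an amide-type nitrogen, so that the (cyclobutylcarbonyl)amino becomes a ((furan-2-yl)carbonyl)amino.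

Among the compounds with values here, no measured pair shows this change. Within the data shown here, the only guide is that compound 1, with a different group on that same carbonyl carbon, gives 110 nM, close to compound 2. A step of similar size, staying within the scatter, is expected from compound 2 to compound 3 in this assay, namely a 1.3-fold lower number from compound 2 to compound 3 (0.10 log units; within the scatter). Compound 3 is therefore estimated at 110 nM, with a range from 50 nM to 260 nM.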

Compound 3, half-maximal inhibitory concentration: > 5000 nM
Compound 3: no number, only a limit; the forecaster's own chance of this, stated with the estimate: 3%; at least 45-fold (1.65 log units) between middle value and limit.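

In this assay, putting furan-2-yl in place of cyclobutyl on a carbonyl carbon gives an at least 35-fold higher number from compound 2 to compound 3 (1.55 log units; beyond the scatter), so this position is far from indifferent to the group it carries, even though the two groups are close in size by heavy-atom count. Compound 3 has no number, only a limit of the assay: the limit of > 5000 nM in this assay, at which 1 of the 3 values shown sits. Within the data shown here, compound 1 and compound 2 differ in more than one place, so their values could not isolate this position, whereas this single change does so for the first time, swapping a four-membered non-aromatic ring of carbon only for a five-membered aromatic ring with one hetero atom.

The compounds shown do not separate what in this change matters: the aromatic ring, the ring oxygen, the ring size or the hydrogen-bond acceptor that furan-2-yl adds. Cyclopentyl on the same carbonyl carbon would keep a five-membered ring of carbon only, and tetrahydrofuran-2-yl would keep the ring oxygen without the aromatic ring, so each would pull these features apart.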